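Chain shortening by ethyl across two cores

This account rests on a few compounds, and the source may have more. Where it says the series, first, only, none or still open, it means among the compounds named here.

Measured compounds:
compound 1 `CCCCc1cc2cn(COCCO)c(O)nc-2n1`: > 200000 nM
compound 2 `CCCCCCCCCCc1cc2cn(COCCO)c(=O)nc2o1`: > 200000 nM
compound 3 `CCCCCCc1cc2cn(COCCO)c(O)nc-2n1`: > 200000 nM

In a functional assay on HEL cells (Homo sapiens) (a lower number here means that less compound is tolerated, a higher number that more compound is tolerated), compound 1 gives only the limit > 200000 nM. Compound 3 gives only the limit > 200000 nM in this assay. Compound 2 likewise gives only the limit > 200000 nM. The step that the two limits leave unreadable from compound 3 to compound 1, the change (hydrogen in place of ethyl on a saturated chain carbon, four bonds along the chain from an aromatic carbon), stays unreadable, as both ends are limits.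

Compound 4 `CCCCCCCCc1cc2cn(COCCO)c(=O)nc2o1` is not yet measured; it differs from compound 2 by hydrogen in place of ethyl on a saturated chain carbon, eight bonds along the chain from an aromatic carbon. This is the same kind of change as from compound 3 to compound 1, but the place differs: four bonds along the chain from an aromatic carbon there, eight bonds along the chain from an aromatic carbon here. The difference between the core of compound 2 and the core of compound 3 is not broken down here.

The step that the limit leaves unreadable from compound 2 to compound 4 is expected to be small because of the limit of > 200000 nM in this assay, at which 3 of the 3 values shown sit. Compound 4 is expected at 300000 nM, most likely reported again only as a limit. Its expected range runs from 150000 nM to 1000000 nM.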

Compound 4, half-maximal cytotoxic concentration: > 200000 nM
Compound 4: no number, only a limit; the forecaster's own chance of this, stated with the estimate: 90%; the middle value lies beyond the limit too.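

In this assay compound 2 and compound 4 both give only limits, and no new step can be read from them. The compounds shown leave open where the half-maximal cytotoxic concentration of any of the four lies, and whether chain length matters on either core.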